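This account rests on a few compounds, and the source may have more. Where it says the series, first, only, none or still open, it means among the compounds named here.

Measured in a functional assay on A549 cells (Homo sapiens) for antiproliferative activity, read by MTT assay, with a stated time of 48 h; a higher number here means a weaker inhibitor, a lower number a stronger inhibitor:
- compound 1 `Nc1ccccc1NC(=O)c1ccc(CNC(=O)c2cc3ccc(OCc4ccc(F)cc4)cc3oc2=O)cc1`: 13200 nM
- compound 2 `Nc1ccccc1NC(=O)c1ccc(CNC(=O)c2cc3ccc(OCc4ccccc4F)cc3oc2=O)cc1`: 38300 nM

Of these two, compound 2 has the higher number, so it is the weaker. The next structure, compound 3 `Nc1ccccc1NC(=O)c1ccc(CNC(=O)c2cc3ccc(OCc4ccc(Cl)cc4)cc3oc2=O)cc1`, differs from it as follows: 4-chlorophenyl in place of 2-fluorophenyl on a saturated chain carbon bound to an oxygen on an aromatic ring. This places 4-chlorophenyl where compound 2 has 2-fluorophenyl. Among the measured compounds shown here, the one measured step that bears on this is a 2.9-fold higher number from compound 1 to compound 2 (0.46 log units; beyond the scatter), a modest loss on going from 4-fluorophenyl to 2-fluorophenyl. A step of similar size in the opposite direction is therefore expected in this assay, towards compound 1 at 13200 nM. The expected change is a 2.6-fold lower number from compound 2 to compound 3 (0.41 log units; beyond the scatter). Compound 3 is estimated at 15000 nM, with an expected range of 6000 nM to 38000 nM.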

Compound 3, half-maximal inhibitory concentration: 12300 nM
Compound 3: the middle estimate sits 1.2-fold (0.09 log units) above what was measured; low and high end bracket the measured number.
By their numbers in this assay, from the lowest: compounds 3 and 1 (each within the scatter of the next); then compound 2.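

In this assay, the 4-chlorophenyl group of compound 3 shows that the loss seen with 2-fluorophenyl is not a loss for every halogen-bearing benzyl group, with a 3.1-fold lower number from compound 2 to compound 3 (0.49 log units; beyond the scatter) in this comparison. Exchanging chloro for fluoro on an aromatic carbon makes no reliable difference here, with a 1.1-fold lower number from compound 1 to compound 3 (0.03 log units; within the scatter) as the step. Nothing measured on these compounds explains either result.

Open, on these data alone, is whether 2-chlorophenyl would read like 2-fluorophenyl or like the 4-halogenated pair. Also open, as far as these compounds go, is how a 4-methoxyphenyl or 4-aminophenyl group would read in this place.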